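Cytotoxicity notes on three measured analogues and one pending

A few compounds are considered here, and "the series" means these few. Any claim that something is new, unique, unknown or untested is made for them only; others in the source may bear on it.

compound 1 `Cc1cc(O)c(C(=O)/C=C/c2cccc3ccccc23)c(-c2ccc(Cl)cc2)c1C(=O)/C=C/c1cccc2ccccc12` — 30000 nM
compound 2 `Cc1cc(O)c(C(=O)/C=C/c2ccccc2Cl)c(-c2ccc(Cl)cc2)c1C(=O)/C=C/c1ccccc1Cl` — 30000 nM
compound 3 `Cc1cc(O)c(C(=O)/C=C/c2ccc(OCc3ccccc3)cc2)c(-c2ccc(Br)cc2)c1C(=O)/C=C/c1ccc(OCc2ccccc2)cc1` — 25000 nM

All three numbers come from an ADME assay on HEK293 cells (Homo sapiens) for cytotoxicity, read by MTT assay, with a stated time of 24 h; a higher number here means a weaker inhibitor, a lower number a stronger inhibitor. Compound 1 stands level with compound 2 at the digits given, and these two are together the highest of the three numbers; compound 3 gives a number that differs from compound 1 by less than the scatter, so nothing separates the three measured compounds in this assay. Within the data shown here, none of the pairs shares a single-point change, so no step between measured compounds can be read off.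

Compound 4 `Cc1cc(O)c(C(=O)/C=C/c2cccc3ccccc23)c(-c2ccccc2)c1C(=O)/C=C/c1cccc2ccccc12` is the next compound for this assay. It differs from compound 1 by hydrogen in place of chloro on an aromatic carbon. With no measured step of this kind in the series and three numbers that sit together, the expectation for the step from compound 1 to compound 4 is none beyond the scatter, no change at the digits printed from compound 1 to compound 4 (within the scatter). Compound 4 is accordingly estimated at 30000 nM in this assay, with a range from 15000 nM to 60000 nM.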

Compound 4, half-maximal inhibitory concentration: "not active" (no number reported)
Compound 4: no number reported, and the estimate cannot be compared.
By their numbers in this assay, from the lowest: compounds 3, 1 and 2 (each within the scatter of the next).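

In this assay, among these compounds, compound 4 is reported as not active, without a number, and no step from compound 1 to compound 4 can be read. The compounds shown leave open how 4-chlorophenyl to phenyl bears on the number in this series. No evidence at hand bears on this result.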